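Swapping tert-butyl for bromo on an aryl fumarate

A few compounds are considered here, and "the series" means these few. Any claim that something is new, unique, unknown or untested is made for them only; others in the source may bear on it.

Measured so far:
- compound 1, `O=C(O)/C=C/C(=O)c1ccc(Cl)cc1Cl`: 62900 nM
- compound 2, `CC(C)c1ccc(C(C)C)c(C(=O)/C=C/C(=O)O)c1`: 4750 nM
- compound 3, `CC(C)(C)c1ccc(C(=O)/C=C/C(=O)O)cc1`: 5100 nM

In a functional assay on HeLa cells (Homo sapiens) for inhibition, read by MTT assay, with a stated time of 72 h (on this read-out lower numbers stand for stronger inhibition and higher numbers for weaker inhibition), compound 3 gives 5100 nM, the second highest of the three numbers. Compound 2 sits closest, within the usual scatter, so the two cannot be ordered. Compound 1, which carries two chloro groups, gives a far higher number, a gap beyond the scatter.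

Compound 4, `O=C(O)/C=C/C(=O)c1ccc(Br)cc1`, is not yet measured. It differs from compound 3 by bromo in place of tert-butyl on an aromatic carbon, on the same aromatic carbon para to a group of 7 heavy atoms. Compound 1 shows that halogen substitution on the ring can go with a much higher number, though its pattern differs. A moderate rise, beyond the scatter, is expected in this assay: the estimated step is a 2.9-fold higher number from compound 3 to compound 4 (0.47 log units; beyond the scatter). Compound 4 is expected to give about 15000 nM, between 5000 nM and 45000 nM.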

Compound 4, half-maximal inhibitory concentration: 18700 nM
For compound 4 the middle estimate is 1.2-fold (0.10 log units) below the measured one; the measured number falls inside the stated range.
By their numbers in this assay, from the lowest: compounds 2 and 3 (each within the scatter of the next); then compound 4; then compound 1.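

In this assay, bromo in place of tert-butyl on this aromatic carbon gives a 3.7-fold higher number from compound 3 to compound 4 (0.56 log units; beyond the scatter), a modest step but one beyond the scatter. Among these compounds, this is the first comparison in which only this group changes, and it shows that the number responds to what sits at this position. Nothing measured here explains the step.

The compounds shown leave open how an amine, a methoxy group or a trifluoromethyl group on this same aromatic carbon would compare with tert-butyl and bromo. They also leave open whether this swap would give a similar step on a ring carrying other groups.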